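Series notes: from compound 1 to compound 3

The compounds below may be only part of what the source reports. "The series", "measured", "known", "first", "only" and "open" are said of these compounds alone.

In a functional assay on A-375 cells (Homo sapiens) for antiproliferative activity, read by CCK-8 assay, with a stated time of 72 h, tested at 8 uM (on this read-out higher numbers stand for a stronger effect at the one concentration tested and lower numbers for a weaker effect), compound 1 `Nc1ccccc1NC(=O)c1ccc(CSC(=S)N2CCN(Cc3ccccn3)CC2)cc1` gives 82.4%, and compound 2 `CN(C(=S)SCc1ccc(C(=O)Nc2ccccc2N)cc1)c1cccnc1` gives 87.7%; the two numbers lie within the scatter of each other, so neither one stands apart. Compound 3 `Nc1ccccc1NC(=O)c1ccc(CSC(=S)N2CCN(c3ccc(F)cc3)CC2)cc1` has not yet been measured. It differs from compound 1 as follows: 4-fluorophenyl in place of (pyridin-2-yl)methyl on an amine nitrogen in a ring. Among the measured compounds shown here, no measured pair of compounds shows a change of this kind, so there is no step to lean on. Compound 3 is expected to show no step beyond the scatter, which is the expected a number 2.4 percentage points lower from compound 1 to compound 3 (within the scatter). The estimate for compound 3 is 80%, with a range from 60% to 95%.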

Compound 3, a percentage reported as inhibition, at one concentration (the size of the read-out at that concentration, not a potency): 76.3%
For compound 3 the middle estimate is 3.7 percentage points above the measured one, within the range that was stated.
By their numbers in this assay, from the lowest: compounds 3, 1 and 2 (each within the scatter of the next, the first and the last beyond it).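

In this assay, 4-fluorophenyl in place of (pyridin-2-yl)methyl on the amine nitrogen in the ring gives a number 6.1 percentage points lower from compound 1 to compound 3 (within the scatter). This position thus accepts an aromatic ring of carbon only, without the hydrogen-bond acceptor of the leaving group, with no step beyond the scatter. No evidence bears on the reason for this result. Still open, on these data alone, is whether a benzyl group or a pyridin-2-yl group on the same nitrogen would separate the change of ring from the loss of the methylene link. Values at one concentration also leave potency open.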